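Working notes: compound 3 to compound 4 in cytotoxicity

The source may hold more compounds than are shown below. What is called first, only, known or untested is meant among the compounds shown, and "the series" means these compounds.

Measured so far:
Compound 1 `O=C(Nc1ccc(Oc2ccnc3[nH]ccc23)cc1)c1nccc(-c2cccc(Cl)c2)n1` in a functional assay on PC-3 cells (Homo sapiens) for cytotoxicity, read by MTT assay, with a stated time of 72 h; a lower number here means a stronger inhibitor, a higher number a weaker inhibitor: 7800 nM
Compound 2 `O=C(Nc1ccc(Oc2ccnc3[nH]ccc23)cc1)c1nccc(-c2ccc(F)cc2)n1` in this assay: "not active" (no number reported)
Compound 3 `COc1ccc(-c2cc(C(=O)Nc3ccc(Oc4ccnc5[nH]ccc45)cc3)ncn2)cc1` in this assay: 9830 nM

Three compounds sharing one core have been run in this assay. Compound 2 was reported without a single number, so only compound 1 and compound 3 give values to compare. Those two values lie within the scatter of each other, so nothing separates compound 3 from compound 1 on the numbers in hand; both sit at the weak end of what this assay resolves.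

Compound 4 `O=C(Nc1ccc(Oc2ccnc3[nH]ccc23)cc1)c1cc(-c2ccc(C(F)(F)F)cc2)ncn1` is the next entry and has not yet been run in this assay. It differs from compound 3 by trifluoromethyl in place of methoxy on an aromatic carbon. Going by the values given here, no step between two measured compounds covers this change, so there is no measured precedent for it. The expectation is therefore anchored on compound 3 at 9830 nM, with a step of a 1.1-fold lower number from compound 3 to compound 4 (0.04 log units; within the scatter) expected, that is, no movement beyond the scatter in either direction. For compound 4 the estimate in this assay is 9000 nM, with a range from 3000 nM to 30000 nM, and a real chance that this assay again reports no number, as it did for compound 2.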

Compound 4, half-maximal inhibitory concentration: 2160 nM
Beside the measured number, compound 4's estimate is 4.2-fold (0.62 log units) above it, outside the stated range (below it).
By their numbers in this assay, from the lowest: compound 4; then compounds 1 and 3 (each within the scatter of the next).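

In this assay, going by these compounds alone, trifluoromethyl in place of methoxy on an aromatic carbon of the six-membered aromatic ring of carbon only, para to a large group, gives a 4.6-fold lower number from compound 3 to compound 4 (0.66 log units; beyond the scatter), the only step so far between two measured compounds that differ in one place. It shows that the group at this carbon can move the cytotoxicity number beyond the scatter with the rest of the molecule unchanged, which the earlier values could not show, as compound 1 and compound 2 differ from compound 3 in more than one place. Nothing in the data shown accounts for the size or direction of this step.

Still open, going by these compounds, is whether the lower number follows from methoxy leaving or from trifluoromethyl entering, a question that a plain hydrogen, a nitrile or a dimethylamino group on the same carbon would help to settle. Also open, on these data alone, is whether the 4-methoxyphenyl to 4-(trifluoromethyl)phenyl exchange gives a similar step on the core of compound 1, the core that compound 2 shares.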